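A few compounds are considered here, and "the series" means these few. Any claim that something is new, unique, unknown or untested is made for them only; others in the source may bear on it.

Compound 2 `Cc1cn([C@@H]2C[C@H](O)[C@@H](CNC(=O)Nc3ccc(-c4ccc(C(F)(F)F)nc4)cc3)O2)c(=O)[nH]c1=O` sits at the upper limit of an ADME assay on MRC5 cells (Homo sapiens) for cytotoxicity; a higher number here means that more compound is tolerated, a lower number that less compound is tolerated: in this assay compound 2 gives > 50000 nM, a limit rather than a number. Compound 1 `Cc1cn([C@@H]2C[C@H](O)[C@@H](CNC(=O)Nc3ccc(Br)cc3)O2)c(=O)[nH]c1=O` likewise gives > 50000 nM, also a limit. Among the measured compounds shown here, the only measured step, a step that the two limits leave unreadable from compound 1 to compound 2, cannot be read because of the limit of > 50000 nM in this assay, at which 2 of the 2 values shown sit. Compound 3 `COc1ccc(COc2ccc(NC(=O)NC[C@H]3O[C@H](n4cc(C)c(=O)[nH]c4=O)C[C@@H]3O)cc2)cc1` differs from compound 2 by (4-methoxybenzyl)oxy in place of 6-(trifluoromethyl)pyridin-3-yl on an aromatic carbon. No readable step bears on this change. The step is expected to be a step that the limit leaves unreadable from compound 2 to compound 3, again hidden within the limit. Compound 3 is therefore estimated at 60000 nM, with a range from 20000 nM to 150000 nM, most likely reported once more only as a limit.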

Compound 3, half-maximal cytotoxic concentration: > 50000 nM
Compound 3: no number, only a limit; the forecaster's own chance of this, stated with the estimate: 75%; the middle value does not contradict the limit.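

No new step can be read among compound 1, compound 2 and compound 3 in this assay, because all three give only a limit: the limit of > 50000 nM in this assay, at which 3 of the 3 values shown sit. The compounds shown leave open whether the bromo, 6-(trifluoromethyl)pyridin-3-yl and (4-methoxybenzyl)oxy groups differ at all in the concentration tolerated.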